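This account rests on a few compounds, and the source may have more. Where it says the series, first, only, none or still open, it means among the compounds named here.

Measured so far:
- compound 1 `CCOC(=O)C(C(=O)c1ccc(OC)cc1)C(NC(C)=O)c1ccc(C(C)C)cc1`: 96.5%
- compound 2 `CCOC(=O)C(C(=O)c1ccc(OC)cc1)C(NC(C)=O)c1cccc2ccccc12`: 98.7%
- compound 3 `CCOC(=O)C(C(=O)c1ccc(OC)cc1)C(NC(C)=O)c1cc(OC)c(OC)c(OC)c1`: 94.3%

Among the compounds with values here, in an ADME assay on Vero cells (Chlorocebus sabaeus) for cytotoxicity, read by MTT assay, tested at 50 uM (a lower number here means a stronger effect, a higher number a weaker effect of the compound at the concentration tested), compound 2 gives 98.7%, numerically the top of the three numbers, but both compound 1 and compound 3 sit within the scatter of it, so no compound stands apart. Compound 4 `CCOC(=O)C(C(=O)c1ccc(OC)cc1)C(NC(C)=O)c1cc(OC)ccc1Br` is not yet measured. It differs from compound 2 by 2-bromo-5-methoxyphenyl in place of naphthalen-1-yl on a saturated chain carbon bound to an amide-type nitrogen and a saturated chain carbon. Within the data shown here, the one measured step at this same place, a number 2.2 percentage points higher from compound 1 to compound 2 (within the scatter), exchanged one aromatic group for another and stayed within the scatter; the change to compound 4 is of the same kind. No step beyond the scatter is therefore expected, and the expected step is a number 2.7 percentage points lower from compound 2 to compound 4 (within the scatter). For compound 4 the estimate in this assay is 96%, with a range from 88% to 101%.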

Compound 4, a percentage reported as activity, at one concentration (the size of the read-out at that concentration, not a potency): 93.3%
Estimate against measurement, compound 4: 2.7 percentage points above, and the stated range covers the measured number.
By their numbers in this assay, from the lowest: compounds 4, 3, 1 and 2 (each within the scatter of the next).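

In this assay, the place on a saturated chain carbon bound to an amide-type nitrogen and a saturated chain carbon also accepts 2-bromo-5-methoxyphenyl: the steps read a number 5.4 percentage points lower from compound 2 to compound 4 (within the scatter) and a number 3.2 percentage points lower from compound 1 to compound 4 (within the scatter). Within these compounds, a single ring bearing bromine and a methoxy group therefore reads alike to naphthalen-1-yl and 4-isopropylphenyl. Nothing available explains this reading.

All groups shown at this place are aromatic, so the effect of an amine, a carboxylic acid or a longer alkyl chain there stays open. Changes to the ethyl ester also stay open.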